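The compounds below may be only part of what the source reports. "The series", "measured", "known", "first", "only" and "open" are said of these compounds alone.

Measured in a functional assay on B16-F0 cells (Mus musculus) for inhibition, read by CCK-8 assay, with a stated time of 48 h; a higher number here means a weaker inhibitor, a lower number a stronger inhibitor:
- Compound 1 `COc1cc(-c2ccnc3cc(-c4ccc(Cl)cc4)nn23)cc(OC)c1OC`: 4090 nM
- Compound 2 `COc1cc(-c2ccnc3cc(-c4ccccc4)nn23)cc(OC)c1OC`: 4730 nM

For the measured compounds named here, compound 2 cannot be separated from compound 1 on these numbers, since the only measured step, a 1.2-fold higher number from compound 1 to compound 2 (0.06 log units; within the scatter), lies within the scatter. Compound 3 `COc1cc(-c2ccnc3cc(-c4ccc5cc[nH]c5c4)nn23)cc(OC)c1OC` keeps the shared core but has 1H-indol-6-yl in place of phenyl on an aromatic carbon. That measured step concerns only hydrogen in place of chloro, so it says little about exchanging the whole group. A real change in this assay towards a lower number is therefore expected, though its size is poorly defined. The estimated step is a 12-fold lower number from compound 2 to compound 3 (1.07 log units; beyond the scatter). For compound 3 the expected value is 400 nM, with an estimated range of 30 nM to 5000 nM.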

Compound 3, half-maximal inhibitory concentration: 55 nM
For compound 3 the middle estimate is 7.3-fold (0.86 log units) above the measured one; low and high end bracket the measured number.
By their numbers in this assay, from the lowest: compound 3; then compounds 1 and 2 (each within the scatter of the next).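

In this assay, the aromatic carbon that carried phenyl or 4-chlorophenyl turns out to be sensitive to the group placed there, which the exchange of chloro for hydrogen had not revealed. 1H-indol-6-yl in place of phenyl gives an 86-fold lower number from compound 2 to compound 3 (1.93 log units; beyond the scatter), and 1H-indol-6-yl in place of 4-chlorophenyl gives a 74-fold lower number from compound 1 to compound 3 (1.87 log units; beyond the scatter). Nothing available explains this gain. The compounds shown leave open whether the gain needs the ring hydrogen on nitrogen of the indole, and whether 1H-indol-5-yl or an aminophenyl group would serve equally at this position.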